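This account rests on a few compounds, and the source may have more. Where it says the series, first, only, none or still open, it means among the compounds named here.

Compound 1 `CCOc1cc(CCc2nc(C)c(CC)s2)nc(NCc2cc(Cl)cc(NC(=O)OC(C)C)c2)c1` gives 33 nM in an assay on cells for binding affinity to Neuropeptide Y receptor type 1 (Homo sapiens); on this read-out higher numbers stand for weaker inhibition and lower numbers for stronger inhibition. Compound 2 `CCc1sc(CCc2cc(OC3CCCC3)cc(NCc3cc(Cl)cc(NC(=O)OC(C)C)c3)n2)nc1C` gives 11 nM, and compound 3 `CCc1sc(CCc2cc(OC3CCOCC3)cc(NCc3cc(Cl)cc(NC(=O)OC(C)C)c3)n2)nc1C` gives 4.4 nM, the lowest of the three numbers: a 7.5-fold lower number from compound 1 to compound 3 (0.88 log units; beyond the scatter) and a 2.5-fold lower number from compound 2 to compound 3 (0.40 log units; beyond the scatter), both beyond the scatter. The unmeasured compound 4 `CCc1sc(CCc2cc(OCc3ccccc3)cc(NCc3cc(Cl)cc(NC(=O)OC(C)C)c3)n2)nc1C` differs from compound 3 by benzyl in place of oxan-4-yl on an oxygen on an aromatic ring. For the measured compounds named here, no measured step makes this exact exchange. The nearest guides are a 3.0-fold lower number from compound 1 to compound 2 (0.48 log units; beyond the scatter) and a 7.5-fold lower number from compound 1 to compound 3 (0.88 log units; beyond the scatter), showing that both ring groups on that oxygen gave lower numbers than ethyl, while a 2.5-fold lower number from compound 2 to compound 3 (0.40 log units; beyond the scatter) shows the carbon-only ring giving the higher number of the two. A somewhat higher number than for compound 3 is therefore expected, and the estimated step is a 2.0-fold higher number from compound 3 to compound 4 (0.31 log units; beyond the scatter). The estimate for compound 4 is 9 nM, with a range from 3.5 nM to 25 nM.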

Compound 4, half-maximal inhibitory concentration: 237 nM
The estimate for compound 4 lay 26-fold (1.42 log units) below the measured number; the whole stated range lies below it.
By their numbers in this assay, from the lowest: compound 3; then compound 2; then compound 1; then compound 4.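

On this oxygen, benzyl reverses what the two saturated rings showed, with a 54-fold higher number from compound 3 to compound 4 (1.73 log units; beyond the scatter) and a 22-fold higher number from compound 2 to compound 4 (1.33 log units; beyond the scatter) in the same direction. It also falls behind the small ethyl group, with a 7.2-fold higher number from compound 1 to compound 4 (0.86 log units; beyond the scatter) showing that a ring on this oxygen does not by itself give a lower number. No available evidence accounts for this reversal.

On these data alone, whether the aromatic ring or its carbon link drives the loss stays open. So does whether a phenyl, pyridin-4-ylmethyl or cyclohexylmethyl group on the same oxygen would behave like benzyl.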